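A few compounds are considered here, and "the series" means these few. Any claim that something is new, unique, unknown or untested is made for them only; others in the source may bear on it.

Measured so far: compound 1 `CN(C(=O)NC(=O)c1ccccc1F)c1nc(C(F)(F)F)c(C(=O)N/N=C/c2ccccc2C(F)(F)F)s1` gives 5.39 ug/mL in a functional assay on HepG2 cells (Homo sapiens) for inhibition, read by MTT assay, with a stated time of 72 h (a higher number here means a weaker inhibitor, a lower number a stronger inhibitor), and compound 2 `CN(C(=O)NC(=O)c1cccc(C(F)(F)F)c1)c1nc(C(F)(F)F)c(C(=O)N/N=C/c2ccccc2C(F)(F)F)s1` gives 10.4 ug/mL.

Compound 2 stands at the top of the two numbers, within the scatter of compound 1. Compound 3 `CN(C(=O)NC(=O)c1cccc([N+](=O)[O-])c1)c1nc(C(F)(F)F)c(C(=O)N/N=C/c2ccccc2C(F)(F)F)s1` differs from it by nitro in place of trifluoromethyl on an aromatic carbon. Going by the values given here, no measured step exchanges these two groups. Among the compounds with values here, the only step available, a 1.9-fold higher number from compound 1 to compound 2 (0.29 log units; within the scatter), changed the group on that same carbonyl and stayed within the scatter, so no shift beyond the scatter is expected in this assay . Compound 3 is therefore estimated at 9 ug/mL, with a range from 4 ug/mL to 20 ug/mL. The expected step is a 1.2-fold lower number from compound 2 to compound 3 (0.06 log units; within the scatter).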

Compound 3, half-maximal inhibitory concentration: 4.8 ug/mL
Beside the measured number, compound 3's estimate is 1.9-fold (0.27 log units) above it; the range from low to high includes it.
By their numbers in this assay, from the lowest: compounds 3, 1 and 2 (each within the scatter of the next, the first and the last beyond it).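

In this assay, nitro in place of trifluoromethyl on the aromatic carbon gives a 2.2-fold lower number from compound 2 to compound 3 (0.34 log units; beyond the scatter), a modest step but the first beyond the scatter, so a change of group at this position can register. By contrast, a 1.1-fold lower number from compound 1 to compound 3 (0.05 log units; within the scatter), so 3-nitrophenyl and 2-fluorophenyl on the carbonyl cannot be told apart here. Nothing available bears on why nitro and trifluoromethyl differ. Going by these compounds, whether an amine or a carboxylic acid on this carbon would move the number further stays open, as does whether the step holds with nitro elsewhere on the ring.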